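The source may report more compounds than this note shows. Statements on the series, on what has been measured and on what is new or still open speak of the compounds shown alone.

Three compounds sharing one core have numbers in a functional assay on MCF7 cells (Homo sapiens) for antiproliferative activity, read by MTT assay, with a stated time of 72 h; a higher number here means a weaker inhibitor, a lower number a stronger inhibitor. Compound 1 `COc1cc(-n2cnc3ccc(-c4ccc([N+](=O)[O-])cc4)cc32)cc(OC)c1OC`, with a nitro group on its phenyl ring, gives 740 nM. Compound 2 `COc1cc(-n2cnc3ccc(-c4ccccc4)cc32)cc(OC)c1OC`, with hydrogen there, gives 2290 nM. Compound 3 `COc1cc(-n2cnc3ccc(-c4ccc(C(F)(F)F)cc4)cc32)cc(OC)c1OC`, with trifluoromethyl there, gives 760 nM. Compound 3 thus stands level with compound 1, shown by a 1.0-fold higher number from compound 1 to compound 3 (0.01 log units; within the scatter), and clearly lower than compound 2, shown by a 3.0-fold lower number from compound 2 to compound 3 (0.48 log units; beyond the scatter). Removing the nitro group gave a step of similar size, a 3.1-fold higher number from compound 1 to compound 2 (0.49 log units; beyond the scatter).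

Compound 4 `COc1cc(-n2cnc3ccc(-c4cccc(N)c4)cc32)cc(OC)c1OC` differs from compound 3 by 3-aminophenyl in place of 4-(trifluoromethyl)phenyl on an aromatic carbon. Among the measured compounds shown here, no measured compound carries an amino group, so the data test this group only indirectly. The closest guide is a 3.0-fold lower number from compound 2 to compound 3 (0.48 log units; beyond the scatter), which suggests that losing the trifluoromethyl may raise the number, with compound 2 as a rough upper reference. The expected change is a 2.1-fold higher number from compound 3 to compound 4 (0.32 log units; beyond the scatter), a modest weakening. For compound 4 the estimated value is 1600 nM, with an expected range from 550 nM to 4500 nM.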

Compound 4, half-maximal inhibitory concentration: 180 nM
The estimate for compound 4 lay 8.9-fold (0.95 log units) above the measured number; measured number below the stated range.
By their numbers in this assay, from the lowest: compound 4; then compounds 1 and 3 (each within the scatter of the next); then compound 2.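

In this assay, placing an amino group on the plain phenyl ring gives the largest step seen at this position, a 13-fold lower number from compound 2 to compound 4 (1.10 log units; beyond the scatter). The nitro and trifluoromethyl compounds had stood level, which might have suggested a limit for changes on this ring, but the 3-aminophenyl group goes clearly past both, with a 4.2-fold lower number from compound 3 to compound 4 (0.63 log units; beyond the scatter) and a 4.1-fold lower number from compound 1 to compound 4 (0.61 log units; beyond the scatter). No measurement at hand explains this gain.

The group and its place on the ring both differ from the earlier substituted compounds, so a 4-aminophenyl compound would be needed to show which of the two matters. A hydroxyl or a methylamino group in place of the amino would further test whether the gain is specific to the amino group.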